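Trimethoxyphenyl in Place of Chlorophenyl on a Shared Core

This account rests on a few compounds, and the source may have more. Where it says the series, first, only, none or still open, it means among the compounds named here.

Compound 1, `COc1cc(/C=C/C(=O)c2cccc(-n3cc(-c4ccccc4)[nH]c3=O)c2)cc(OC)c1OC`: 2300 nM
Compound 2, `COc1ccc(-c2cn(-c3cccc(C(=O)/C=C/c4cc(OC)c(OC)c(OC)c4)c3)c(=O)[nH]2)cc1`: 4200 nM
Compound 3, `COc1cc(/C=C/C(=O)c2cccc(-n3cc(-c4ccc(Cl)cc4)[nH]c3=O)c2)cc(OC)c1OC`: "not active" (no number reported)

These three compounds share one core and differ only in the phenyl group attached to the five-membered ring. In a functional assay on EKVX cells (Homo sapiens) for inhibition (a higher number here means a weaker inhibitor of growth, a lower number a stronger inhibitor of growth), compound 1 gives 2300 nM, and compound 2 gives 4200 nM; the step of a 1.8-fold higher number from compound 1 to compound 2 (0.26 log units; within the scatter) lies within the scatter. Going by the values given here, compound 3 returned no number in this assay and is recorded as "not active" (no number reported), so it cannot be placed on the scale of compounds 1 and 2, and no step to or from it can be sized.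

Compound 4, `COc1cc(/C=C/C(=O)c2cccc(-n3cc(-c4cc(OC)c(OC)c(OC)c4)[nH]c3=O)c2)cc(OC)c1OC`, has not yet been measured. It differs from compound 3 by 3,4,5-trimethoxyphenyl in place of 4-chlorophenyl on an aromatic carbon. Among the compounds with values here, no measured step covers this change directly. Within the data shown here, the only step that concerns the same phenyl group, a 1.8-fold higher number from compound 1 to compound 2 (0.26 log units; within the scatter), was within the scatter, and compound 3 offers no number from which a direction could be read. Compound 4 is therefore expected to give about 5000 nM in this assay, with a likely range from 1500 nM to 20000 nM.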

Compound 4, concentration for 50% growth inhibition: 9470 nM
Beside the measured number, compound 4's estimate is 1.9-fold (0.28 log units) below it; the range from low to high includes it.
By their numbers in this assay, from the lowest: compounds 1 and 2 (each within the scatter of the next); then compound 4.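

In this assay, going by these compounds alone, the 3,4,5-trimethoxyphenyl group brings the first steps on this aromatic carbon that lie beyond the scatter, with a 2.3-fold higher number from compound 2 to compound 4 (0.35 log units; beyond the scatter) and a 4.1-fold higher number from compound 1 to compound 4 (0.61 log units; beyond the scatter) on the shared core. Compound 1 and compound 2 could not be told apart, yet both steps run the same way, so compound 4 is a weaker inhibitor of growth than either. Compound 3 has no number, so steps to or from it cannot be read, and 4-chlorophenyl stays off this scale.

The compounds shown leave open whether a phenyl group carrying an amine or a carboxylic acid at this place would stand with compound 1 and compound 2 or with compound 4. Nothing available here accounts for the higher number of compound 4.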